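The source may hold more compounds than are shown below. What is called first, only, known or untested is meant among the compounds shown, and "the series" means these compounds.

Compound 1, `CC(C)c1cc(Nc2cc(Cl)cc(Cl)c2)nc(N)n1`, in an assay on cells for inhibition of S-adenosylmethionine decarboxylase proenzyme (Homo sapiens), read by mass spectrometry, at pH 7.2 (a lower number here means a stronger inhibitor, a higher number a weaker inhibitor), reaches only the limit > 180000 nM.
Compound 2, `Nc1ccnc(Nc2cc(Cl)cc(Cl)c2)c1`, likewise gives only the limit > 180000 nM.
Compound 3, `Cc1cc(Nc2cc(Br)cc(OCC(F)(F)F)c2)nc(N)n1`, gives a number, 44000 nM.

Among the three, compound 3 thus stands alone with a measured value, while the other two sit at the assay limit (the limit of > 180000 nM in this assay, at which 2 of the 3 values shown sit). No pair of these compounds differs in a single place, so no measured step can be leaned on. Compound 4, `Cc1cc(Nc2cccc(Br)c2)nc(N)n1`, differs from compound 3 by hydrogen in place of 2,2,2-trifluoroethoxy on an aromatic carbon: in words, hydrogen in place of 2,2,2-trifluoroethoxy on an aromatic carbon. Since compound 3 is already weak in this assay at 44000 nM, the expectation is that compound 4 loses rather than gains, by a step beyond the usual scatter, estimated as a 2.5-fold higher number from compound 3 to compound 4 (0.40 log units; beyond the scatter). Compound 4 is therefore expected to give about 110000 nM in this assay, within a range from 30000 nM to 400000 nM, with a real chance that only a limit is reported.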

Compound 4, half-maximal inhibitory concentration: > 180000 nM
Compound 4 ended at the assay's limit; the forecaster's own chance of this, stated with the estimate: 40%; middle value at least 1.6-fold (0.21 log units) away from the limit.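

With hydrogen in place of 2,2,2-trifluoroethoxy on this aromatic carbon, this assay gives an at least 4.0-fold higher number from compound 3 to compound 4 (0.61 log units; beyond the scatter), the only measured step among these compounds, and it lies beyond the scatter. Going by these compounds, the step is a lower bound, since compound 4 gives only a limit, > 180000 nM, so its true size stays unknown. On this core, then, the measurable value of compound 3 depends on the 2,2,2-trifluoroethoxy group, and without it compound 4 falls in with the compounds that give no number: the limit of > 180000 nM in this assay, at which 3 of the 4 values shown sit.

The compounds shown leave open whether the fluorines matter or any ether at this carbon would do, which a methoxy or plain ethoxy group there would test. They also leave open whether an amine or a longer alkoxy chain at the same place would give a stronger number than compound 3.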